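This account rests on a few compounds, and the source may have more. Where it says the series, first, only, none or still open, it means among the compounds named here.

Measured so far in an ADME assay on HCT-116 cells (Homo sapiens) for cytotoxicity, read by CellTiter-Glo, with a stated time of 72 h (on this read-out higher numbers stand for weaker inhibition and lower numbers for stronger inhibition), all three values being limits:
Compound 1 `CC1CCN(C2CCN(S(=O)(=O)c3cccc(C(F)(F)F)c3)CC2)CC1`: > 5000 nM
Compound 2 `CC1CCN(C2CCN(S(=O)(=O)c3cccc(-c4ccc(F)cc4)c3)CC2)CC1`: > 5000 nM
Compound 3 `CC1CCN(C2CCN(S(=O)(=O)c3cccc(-c4ccccc4C(F)(F)F)c3)CC2)CC1`: > 5000 nM

Compound 1 has only a limit and no number, so its place among the three compounds cannot be ranked: the series sits at the limit of > 5000 nM in this assay, at which 3 of the 3 values shown sit. Compound 4 `CC1CCN(C2CCN(S(=O)(=O)c3ccc([N+](=O)[O-])c(C(F)(F)F)c3)CC2)CC1` keeps the core of compound 1 and changes it in one place: nitro in place of hydrogen on an aromatic carbon. The new group stands on an aromatic carbon, ortho to a trifluoromethyl group and para to a large group.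

Three measured steps offer the nearest guidance, though all of them exchange a substituent at a different site. They are a step that the two limits leave unreadable from compound 1 to compound 2, a step that the two limits leave unreadable from compound 1 to compound 3 and a step that the two limits leave unreadable from compound 2 to compound 3. None has a readable size, and none involves a nitro group. They therefore give no basis for expecting a step of any particular size or direction in this assay, and the working expectation is no change beyond the scatter. The expected outcome is a step that the limit leaves unreadable from compound 1 to compound 4, and a reported limit is the likeliest result. For compound 4 the estimated value is 8000 nM, with an expected range from 3000 nM to 20000 nM.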

Compound 4, half-maximal inhibitory concentration: > 5000 nM
Compound 4 was reported as a limit; the forecaster's own chance of this, stated with the estimate: 80%; the middle value does not contradict the limit.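

In this assay compound 4 gives > 5000 nM, which is a limit and not a number. No step from compound 1 to compound 4 can be read, as the whole series stays at a limit: the limit of > 5000 nM in this assay, at which 4 of the 4 values shown sit.

The compounds shown leave open how the four compounds rank and whether nitro in place of hydrogen changes the read-out at all.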